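This account rests on a few compounds, and the source may have more. Where it says the series, first, only, none or still open, it means among the compounds named here.

Compound 1 `CCOC(=O)c1csc2nc(CN3CCN(C)CC3)c(-c3ccc(OC)cc3)n12` and compound 2 `CCOC(=O)c1csc2nc(CN3CCN(C)CC3)c(-c3ccc(Br)cc3)n12` are built on the same core and differ in one place only: bromo in place of methoxy on an aromatic carbon. In a functional assay on MCF7 cells (Homo sapiens) for antiproliferative activity, read by MTT assay, with a stated time of 72 h (on this read-out lower numbers stand for stronger inhibition and higher numbers for weaker inhibition), compound 1 gives 32800 nM, while compound 2 gives 68500 nM, so this single change produced a 2.1-fold higher number from compound 1 to compound 2 (0.32 log units; beyond the scatter). Compound 3 `COc1ccc(-c2c(CN3CCCCC3)nc3scc(C(=O)O)n23)cc1` is built on a different core, and the difference between the two cores is not broken down here. In this assay compound 3 gives 62900 nM, a number that lies within the usual scatter of both compound 2 and compound 1, so no ordering among these three can be read from it. Compound 4 `O=C(O)c1csc2nc(CN3CCCCC3)c(-c3ccc(Br)cc3)n12`, which has not been measured, differs from compound 3 by the same change seen between compound 1 and compound 2: bromo in place of methoxy on an aromatic carbon. This change appears twice among the compounds shown, and its one measured step is the modest one from compound 1 to compound 2. Resting on that step alone, the step from compound 3 to compound 4 in this assay is expected to be a 2.1-fold higher number from compound 3 to compound 4 (0.32 log units; beyond the scatter). Compound 4 is therefore estimated to give 130000 nM. For compound 4 the expected range runs from 60000 nM to 280000 nM.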

Compound 4, half-maximal inhibitory concentration: 87500 nM
Compound 4: middle estimate off by 1.5-fold (0.17 log units), on the high side, within the range that was stated.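

In this assay, moving to the second core, the swap of methoxy for bromo gives a 1.4-fold higher number from compound 3 to compound 4 (0.14 log units; within the scatter), so on this core the step itself cannot be told apart from repeat-measurement noise. Set beside the step on the first core, the two results do not disagree by more than such measurements can resolve: the same change on two cores in this assay, a 2.1-fold higher number (0.32 log units; beyond the scatter) from compound 1 to compound 2 and a 1.4-fold higher number (0.14 log units; within the scatter) from compound 3 to compound 4, 1.5-fold (0.18 log units) apart, within the scatter of two such steps. For the compounds shown here, this means that the change can be carried from one core to the other without any sign of a different outcome, but it does not prove that the step is the same on both cores, since only two pairs are available and only the first lies beyond the scatter.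

The compounds shown leave open whether this holds on any further core, and why the step is beyond the scatter on one core and within it on the other. They also leave open what other groups at the same place would do, such as chloro, an amine or a longer alkoxy chain.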